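Compound 4: 4-chloro-2-methylphenyl replaces 3,4-dimethylphenyl

A few compounds are considered here, and "the series" means these few. Any claim that something is new, unique, unknown or untested is made for them only; others in the source may bear on it.

In a functional assay on MDA-MB-231 cells (Homo sapiens) for cytotoxicity, read by MTT assay, with a stated time of 48 h (on this read-out lower numbers stand for stronger inhibition and higher numbers for weaker inhibition), compound 3 (`Cc1ccc(NC(=O)NCCCCC(c2ccc(F)cc2)c2ccc(F)cc2)cc1C`) gives > 20000 nM, which is a limit and not a number. It sits at the limit of > 20000 nM in this assay, at which 1 of the 3 values shown sits. Two relatives with the same core do give numbers: compound 1 (`O=C(NCCCCC(c1ccc(F)cc1)c1ccc(F)cc1)Nc1ccc(Cl)cc1`) gives 7680 nM, and compound 2 (`O=C(NCCCCC(c1ccc(F)cc1)c1ccc(F)cc1)Nc1cccc([N+](=O)[O-])c1`) gives 3790 nM.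

Compound 4 (`Cc1cc(Cl)ccc1NC(=O)NCCCCC(c1ccc(F)cc1)c1ccc(F)cc1`) differs from compound 3 in one place, on an amide-type nitrogen, where 4-chloro-2-methylphenyl stands in place of 3,4-dimethylphenyl: 4-chloro-2-methylphenyl in place of 3,4-dimethylphenyl on an amide-type nitrogen.

Within the data shown here, three measured steps concern this same place. Going from 4-chlorophenyl to 3-nitrophenyl gives a 2.0-fold lower number from compound 1 to compound 2 (0.31 log units; beyond the scatter). Going to 3,4-dimethylphenyl gives an at least 2.6-fold higher number from compound 1 to compound 3 (0.41 log units; beyond the scatter), and from the nitro compound it gives an at least 5.2-fold higher number from compound 2 to compound 3 (0.72 log units; beyond the scatter). All three are modest or at least modest. The closest guide is compound 1 at 7680 nM, whose 4-chlorophenyl shares the 4-chloro of the entering group. Among the measured compounds shown here, no measured compound carries the methyl of that group, so the guide is only partial.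

A modest move toward a lower number is therefore expected in this assay, and the expected step is an at least 2.0-fold lower number from compound 3 to compound 4 (0.30 log units; that floor lies within the scatter). The estimate for compound 4 is 10000 nM, with an expected range of 4000 nM to 20000 nM.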

Compound 4, half-maximal inhibitory concentration: > 20000 nM
Compound 4: only a limit was reported (the forecaster's own chance of this, stated with the estimate: 25%); at least 2.0-fold (0.30 log units) between middle value and limit.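

In this assay compound 4 gives a limit and not a number, the same limit as compound 3: the limit of > 20000 nM in this assay, at which 2 of the 4 values shown sit. Two limits cannot be compared, so the step between these two compounds cannot be read, but the steps from the compounds with numbers can: adding a single methyl to the 4-chlorophenyl ring gives an at least 2.6-fold higher number from compound 1 to compound 4 (0.41 log units; beyond the scatter), and the change from the 3-nitrophenyl ring gives an at least 5.2-fold higher number from compound 2 to compound 4 (0.72 log units; beyond the scatter). The new finding is that the 4-chloro group does not by itself preserve a measurable value once this methyl is present, and among these four compounds, the two rings carrying methyl groups end at the limit while the two without methyl give numbers.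

Neither limit shows how far compound 3 and compound 4 lie from each other, so any real difference between their rings stays hidden. As far as these compounds go, it also remains open whether the loss is tied to methyl itself, since a ring with fluorine or methoxy in place of that methyl, or an aminophenyl ring on the same nitrogen, could behave quite differently.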